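A few compounds are considered here, and "the series" means these few. Any claim that something is new, unique, unknown or untested is made for them only; others in the source may bear on it.

Measured so far in a functional assay on HepG2 cells (Homo sapiens) for inhibition, read by MTT assay, with a stated time of 48 h; on this read-out lower numbers stand for stronger inhibition of growth and higher numbers for weaker inhibition of growth
compound 1 `Cn1cc(C2CC(c3ccccc3)=NN2C(=O)c2cccnc2)c2ccccc21` gives 4630 nM in this series
compound 2 `COc1cc(C2=NN(C(=O)c3ccc(C)nc3)C(c3cn(C)c4ccccc34)C2)cc(OC)c1OC` gives 310 nM in this series
compound 3 `Cn1cc(C2CC(c3ccccc3)=NN2C(=O)c2cccnc2)c2cc(Br)ccc21` gives 2520 nM in this series

Compound 3 lies within the scatter of compound 1, while compound 2 has a clearly lower number, beyond the scatter. Compound 4 `Cn1cc(C2CC(c3ccc(Cl)cc3)=NN2C(=O)c2cccnc2)c2cc(Br)ccc21` carries chloro in place of hydrogen on an aromatic carbon, phenyl to 4-chlorophenyl (chloro in place of hydrogen on an aromatic carbon). The nearest measured step is a 1.8-fold lower number from compound 1 to compound 3 (0.26 log units; within the scatter), the same kind of exchange with bromo, but elsewhere on the molecule. Compound 2 differs from compound 3 in several places and isolates no single change. What is expected is therefore a 1.4-fold lower number from compound 3 to compound 4 (0.15 log units; within the scatter), so no step beyond the scatter. The estimate for compound 4 is 1800 nM with an expected range from 700 nM to 4500 nM in this series.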

Compound 4, concentration for 50% growth inhibition: 5800 nM
Compound 4: the middle estimate sits 3.2-fold (0.51 log units) below what was measured, and the stated range ends below it.
By their numbers in this assay, from the lowest: compound 2; then compounds 3, 1 and 4 (each within the scatter of the next, the first and the last beyond it).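

In this assay, the phenyl to 4-chlorophenyl exchange gives a 2.3-fold higher number from compound 3 to compound 4 (0.36 log units; beyond the scatter), so growth inhibition weakens modestly with chloro at this place, para to a large group. The earlier halogen step, a 1.8-fold lower number from compound 1 to compound 3 (0.26 log units; within the scatter), showed no such change, so a halogen in place of hydrogen is not neutral at every aromatic carbon of this series, though only these two steps bear on that. No measurement shown accounts for this step.

Going by these compounds, whether an amine or a carboxylic acid at this place would also weaken inhibition remains open. Also open, on these data alone, is whether the chloro step holds in the absence of the bromo.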